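Pyridine for Pyrimidine in Two Antiproliferative Scaffolds

The compounds below may be only part of what the source reports. "The series", "measured", "known", "first", "only" and "open" are said of these compounds alone.

Measured compounds:
compound 1 `CCN(c1ccc(C#N)c(Cl)c1)c1cc(-c2ccncc2)ccc1C`: 1030 nM
compound 2 `CCN(c1ccc(C#N)c(Cl)c1)c1cc(-c2cncnc2)ccc1C`: > 30000 nM
compound 3 `N#Cc1ccc(N2CCc3cc(-c4cncnc4)ccc3C2)cc1C(F)(F)F`: "not determined" (no result reported)

In a functional assay on CWR22R cells (Homo sapiens) for antiproliferative activity, read by CCK-8 assay, with a stated time of 6 days (on this read-out higher numbers stand for weaker inhibition and lower numbers for stronger inhibition), compound 1 gives 1030 nM. For compound 2 the value > 30000 nM is a limit of this assay, not a number. The change pyridin-4-yl in place of pyrimidin-5-yl on an aromatic carbon brought an at least 29-fold lower number from compound 2 to compound 1 (1.46 log units; beyond the scatter), a step whose lower end is set by the limit of > 30000 nM in this assay, at which 1 of the 3 values shown sits. As far as these compounds go, compound 4 `N#Cc1ccc(N2CCc3cc(-c4ccncc4)ccc3C2)cc1C(F)(F)F` is untested; it carries the same kind of change, (pyridin-4-yl in place of pyrimidin-5-yl on an aromatic carbon), but on a different core, where the ring sits meta and para to a fused ring rather than meta to a large group and para to a methyl group. The difference between the two cores is not broken down here, and compound 3 has no measured value in this assay, its entry being "not determined" (no result reported). Compound 4 is expected to fall near 500 nM, most likely within 50 nM to 5000 nM, an estimate resting on the gain seen in an at least 29-fold lower number from compound 2 to compound 1 (1.46 log units; beyond the scatter).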

Compound 4, half-maximal inhibitory concentration: 6940 nM
The estimate for compound 4 lay 14-fold (1.14 log units) below the measured number, and the stated range ends below it.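

Between compound 3 and compound 4 no step can be read in this assay: compound 3 has no number there. Still open is whether pyridin-4-yl in place of pyrimidin-5-yl does on the core of compound 4 what it does on the core of compound 1, where the size of the step rests on a limit: the limit of > 30000 nM in this assay, at which 1 of the 4 values shown sits.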